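Swapping a thiocarbonyl-bearing tail for a bromoalkyl chain

A few compounds are considered here, and "the series" means these few. Any claim that something is new, unique, unknown or untested is made for them only; others in the source may bear on it.

Measured compounds:
- Compound 1, `COc1ccc(-c2coc3cc(OCCCSC(=S)N4CCCC4)ccc3c2=O)cc1`: 40000 nM
- Compound 2, `CCN1CCN(C(=S)SCCCOc2ccc3c(=O)c(-c4ccc(OC)cc4)coc3c2)CC1`: 54000 nM
- Compound 3, `COc1ccc(-c2coc3cc(OCCCSC(=S)N4CCOCC4)ccc3c2=O)cc1`: 49600 nM

The three measured compounds share one core and differ only in the ring attached to the thiocarbonyl carbon at the end of the side chain. In a functional assay on MGC-803 cells (Homo sapiens) for inhibition, read by MTT assay, with a stated time of 48 h (a lower number here means a stronger inhibitor, a higher number a weaker inhibitor), compound 3 gives 49600 nM, the second highest of the three numbers. Its nearest neighbour is compound 2, whose value differs by a 1.1-fold lower number from compound 2 to compound 3 (0.04 log units; within the scatter), and the furthest is compound 1, with a 1.2-fold higher number from compound 1 to compound 3 (0.09 log units; within the scatter). The remaining comparison, a 1.4-fold higher number from compound 1 to compound 2 (0.13 log units; within the scatter), is likewise small. All three ring swaps on the thiocarbonyl carbon therefore leave the number essentially unchanged.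

Compound 4, `COc1ccc(-c2coc3cc(OCCCCCBr)ccc3c2=O)cc1`, makes a different kind of change: a group of 3 heavy atoms (2 carbon, 1 bromine; no ring) in place of a group of 9 heavy atoms (5 carbon, 1 nitrogen, 1 oxygen, 2 sulfur; one six-membered non-aromatic ring with 2 hetero atoms), on a saturated chain carbon, three bonds along the chain from an oxygen on an aromatic ring

For the measured compounds named here, none of the measured steps touches this part of the molecule; each of them only exchanges one ring for another while keeping the thiocarbonyl group. They offer no direct guide to how removing that group and leaving a short brominated chain will behave. Since all three measured values sit close together, the most reasonable expectation is that compound 4 also lands in this weak range, with a wider uncertainty than usual. Compound 4 is therefore estimated at 55000 nM, within 20000 nM to 150000 nM, which is expected to amount to a 1.1-fold higher number from compound 3 to compound 4 (0.04 log units; within the scatter).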

Compound 4, half-maximal inhibitory concentration: > 100000 nM
Compound 4: no number, only a limit; the forecaster's own chance of this, stated with the estimate: 25%; middle value at least 1.8-fold (0.25 log units) away from the limit.
By their numbers in this assay, from the lowest: compounds 1, 3 and 2 (each within the scatter of the next). At a limit, above all of these: compound 4.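

Compound 4 gives no number in this assay, only a limit of the assay, > 100000 nM. The ring swaps on the thiocarbonyl carbon all stayed within the scatter, but replacing the whole end of the side chain with 2-bromoethyl gives an at least 2.5-fold higher number from compound 1 to compound 4 (0.39 log units; beyond the scatter), while the floors of an at least 1.8-fold higher number from compound 2 to compound 4 (0.26 log units; that floor lies within the scatter) and an at least 2.0-fold higher number from compound 3 to compound 4 (0.30 log units; that floor lies within the scatter) lie within the scatter, so only the comparison with compound 1 clearly shows a weaker inhibitor. This position therefore tolerates exchange of the ring but gives the first sign that losing the entire thiocarbonyl-bearing end may matter, and compound 4 alone reaches the ceiling of the read-out: the limit of > 100000 nM in this assay, at which 1 of the 4 values shown sits.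

As far as these compounds go, because the sizes of these steps are only floors, how much weaker compound 4 really is stays unknown, and the change removes the ring, the thiocarbonyl group and both sulfur atoms at once, so their separate contributions cannot be told apart. Also open, from the compounds shown here alone, is how the same chain would behave if it ended in a simple amine such as pyrrolidin-1-yl bonded directly to the chain, or in a plain thioether without the thiocarbonyl group.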